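Tetrazole anilines on hamster cells: a halophenyl swap

The source may report more compounds than this note shows. Statements on the series, on what has been measured and on what is new or still open speak of the compounds shown alone.

Measured compounds:
compound 1, `COc1ccc(Nc2nnnn2-c2ccccc2Br)cc1`, 119000 nM
compound 2, `COc1ccc(-n2nnnc2Nc2ccc(Br)cc2)cc1`, 212000 nM
compound 3, `COc1ccc(-n2nnnc2Nc2cccc(Cl)c2)cc1`, 243000 nM

In an ADME assay on V79 cells (Cricetulus griseus) for cytotoxicity, read by MTT assay, with a stated time of 72 h (on this read-out higher numbers stand for weaker inhibition and lower numbers for stronger inhibition), compound 1 gives 119000 nM, the lowest of the three numbers shown. Compound 2 gives 212000 nM in this assay, a value within the usual scatter of compound 1, so no order between the two can be claimed. Compound 3 gives 243000 nM in this assay, which does lie beyond the scatter of compound 1.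

Among the measured compounds shown here, the one step between measured compounds that differ in a single place is a 1.1-fold higher number from compound 2 to compound 3 (0.06 log units; within the scatter). It exchanges one halophenyl for another on a nitrogen and leaves the number essentially where it was.

Compound 4, `COc1ccc(Nc2nnnn2-c2cccc(F)c2)cc1`, has not yet been measured in this assay. Relative to compound 1 the change is 3-fluorophenyl in place of 2-bromophenyl on an aromatic nitrogen. For the measured compounds named here, the only step that bears on this is a 1.1-fold higher number from compound 2 to compound 3 (0.06 log units; within the scatter), a halophenyl-for-halophenyl exchange that stayed within the scatter, though it sits on a different nitrogen of the shared core. On that basis no step beyond the scatter is expected in this assay for compound 4, and the estimated step is a 1.3-fold higher number from compound 1 to compound 4 (0.10 log units; within the scatter). Compound 4 is therefore expected to give about 150000 nM in this assay, with a likely range from 60000 nM to 350000 nM.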

Compound 4, half-maximal inhibitory concentration: 123000 nM
Estimate against measurement, compound 4: 1.2-fold (0.09 log units) above; the measured number falls inside the stated range.
By their numbers in this assay, from the lowest: compounds 1, 4, 2 and 3 (each within the scatter of the next, the first and the last beyond it).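

In this assay, putting 3-fluorophenyl in place of 2-bromophenyl on the aromatic nitrogen gives a 1.0-fold higher number from compound 1 to compound 4 (0.01 log units; within the scatter), so this position tolerates a change of both the halogen and its place on the phenyl ring without any shift that can be read. The earlier exchange of one halophenyl for another, a 1.1-fold higher number from compound 2 to compound 3 (0.06 log units; within the scatter), also stayed within the scatter, but it lay on a different nitrogen of the shared core, and the new step now gives the same picture at the position held by the 2-bromophenyl group of compound 1. Since halogen and ring position changed together in this one step, their separate contributions cannot be told apart, and two changes that cancel each other cannot be excluded.

Every compound shown carries a halophenyl group, so it remains open whether an unsubstituted phenyl, or a phenyl bearing an amine or a carboxylic acid, would hold the number at this nitrogen. Also open, as far as these compounds go, is whether a longer chain in place of the methoxy group would alter the picture, and no measurement on hand offers an explanation for this result.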